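Moving the methoxy group from compound 2 to compound 3

The compounds below may be only part of what the source reports. "The series", "measured", "known", "first", "only" and "open" are said of these compounds alone.

Measured so far in a functional assay on cells (Homo sapiens) for cytotoxicity, read by MTT assay, with a stated time of 24 h; on this read-out lower numbers stand for stronger inhibition and higher numbers for weaker inhibition
- compound 1 `CCCCCCCCCCCCCCNC(=O)[C@H](CO)/N=C/c1cccc(C)c1` gives 82900 nM
- compound 2 `CCCCCCCCCCCCCCNC(=O)[C@H](CO)/N=C/c1cccc(OC)c1` gives 31300 nM
- compound 3 `CCCCCCCCCCCCCCNC(=O)[C@H](CO)/N=C/c1ccc(OC)cc1` awaits measurement

Compound 2 holds the lower of the two numbers at 31300 nM so far. Compound 3 differs by 4-methoxyphenyl in place of 3-methoxyphenyl on a carbon with a double bond to nitrogen with 4-methoxyphenyl in place of 3-methoxyphenyl on a carbon with a double bond to nitrogen. Within the data shown here, the one measured step of a 2.6-fold lower number from compound 1 to compound 2 (0.42 log units; beyond the scatter) is modest and exchanged methyl for methoxy, so it gives no direct reading on moving the methoxy. In this assay only a small step of no firm direction is therefore expected, with a 1.1-fold higher number from compound 2 to compound 3 (0.05 log units; within the scatter) as the estimated change. For compound 3 the estimate is 35000 nM with 15000 nM to 80000 nM as the expected range.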

Compound 3, half-maximal inhibitory concentration: 28100 nM
The estimate for compound 3 lay 1.2-fold (0.10 log units) above the measured number; low and high end bracket the measured number.
By their numbers in this assay, from the lowest: compounds 3 and 2 (each within the scatter of the next); then compound 1.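

In this assay, 4-methoxyphenyl in place of 3-methoxyphenyl on a carbon with a double bond to nitrogen gives a 1.1-fold lower number from compound 2 to compound 3 (0.05 log units; within the scatter), so this move of the methoxy group does not separate the two compounds. With 4-methoxyphenyl in place of 3-methylphenyl, the series shows a 3.0-fold lower number from compound 1 to compound 3 (0.47 log units; beyond the scatter), so both methoxy compounds now stand apart from the methyl compound beyond the scatter. No measurement at hand explains these results. On these data alone, whether a carboxylic acid or an amine at this position, or a longer chain elsewhere, would shift the number remains open.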